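Working notes: from compound 3 toward compound 4

A few compounds are considered here, and "the series" means these few. Any claim that something is new, unique, unknown or untested is made for them only; others in the source may bear on it.

Three compounds on the shared core have numbers in an ADME assay on microsomes from liver (Rattus norvegicus) for pharmacokinetics; a higher number here means faster removal of the compound, a lower number slower removal. Compound 1 `CNc1nc(-c2cc(-c3ccon3)n(Cc3ccccc3F)n2)ncc1F` gives 160 uL/min in this assay. Compound 2 `Fc1ccccc1Cn1nc(-c2ncc(F)c(N3CCCCC3)n2)cc1-c1ccon1` gives 490 uL/min in this assay. Compound 3 `Fc1ccccc1Cn1nc(-c2ncc(F)c(N3CCC(F)(F)CC3)n2)cc1-c1ccon1` gives 340 uL/min in this assay, the second highest of the three numbers; its nearest neighbour is compound 2, with a 1.4-fold lower number from compound 2 to compound 3 (0.16 log units; within the scatter), and its furthest is compound 1, with a 2.1-fold higher number from compound 1 to compound 3 (0.33 log units; beyond the scatter).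

The measured steps all sit on the same aromatic carbon. Replacing methylamino gave a 3.1-fold higher number from compound 1 to compound 2 (0.49 log units; beyond the scatter) and a 2.1-fold higher number from compound 1 to compound 3 (0.33 log units; beyond the scatter), both modest and beyond the scatter. Exchanging one six-membered ring for another gave a 1.4-fold lower number from compound 2 to compound 3 (0.16 log units; within the scatter), within the scatter.

Compound 4 `OC1CCN(c2nc(-c3cc(-c4ccon4)n(Cc4ccccc4F)n3)ncc2F)CC1` is the next member. Relative to compound 3 the change is 4-hydroxypiperidin-1-yl in place of 4,4-difluoropiperidin-1-yl on an aromatic carbon. For the measured compounds named here, no measured step introduces a hydroxyl or a hydrogen-bond donor, so nothing speaks directly to it. Going by the values given here, the only step that swaps one six-membered ring for another on this carbon, a 1.4-fold lower number from compound 2 to compound 3 (0.16 log units; within the scatter), stayed within the scatter, and a step of similar size is expected here, with no clear direction. For compound 4 the estimate in this assay is 270 uL/min, with a range from 120 uL/min to 550 uL/min. That estimate amounts to an expected step of a 1.3-fold lower number from compound 3 to compound 4 (0.10 log units; within the scatter).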

Compound 4, intrinsic clearance in a liver preparation (reported as CLH), per the amount of preparation that the assay uses: 390 uL/min
For compound 4 the middle estimate is 1.4-fold (0.16 log units) below the measured one; low and high end bracket the measured number.
By their numbers in this assay, from the lowest: compound 1; then compounds 3, 4 and 2 (each within the scatter of the next).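

In this assay a hydroxy group on the saturated ring carbon brings a hydrogen-bond donor to this position, yet the result stays within the scatter against both the unsubstituted ring (a 1.3-fold lower number from compound 2 to compound 4 (0.10 log units; within the scatter)) and the difluorinated ring (a 1.1-fold higher number from compound 3 to compound 4 (0.06 log units; within the scatter)), so hydrogen, fluorine and hydroxy on this ring cannot be told apart in this read-out. The separation from the methylamino compound holds for this ring as well (a 2.4-fold higher number from compound 1 to compound 4 (0.39 log units; beyond the scatter)), so all three piperidine-based groups now stand beyond the scatter from compound 1, and no compound shown goes against that. Nothing available explains why these groups behave alike at this position.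

Still open, as far as these compounds go, is whether the number for compound 1 goes with the smaller substituent or with its amino hydrogen, which a dimethylamino or an ethylamino group on the same carbon could help to separate. Also open, from the compounds shown here alone, is whether any ring substituent can move the number beyond the scatter, for example a carboxylic acid or a basic amine on the piperidine, or a morpholine or pyrrolidine in place of the ring.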